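Aryl sulfamate amides: lipophilicity note on pyridyl analogue

The source may report more compounds than this note shows. Statements on the series, on what has been measured and on what is new or still open speak of the compounds shown alone.

Compound 2 `CCN(Cc1cccc(Br)c1)c1ccc(C(=O)N2CCc3ccc(OS(N)(=O)=O)cc3C2)cc1` gives 1.93 in a physicochemical assay for lipophilicity; a higher number here means a more lipophilic compound, a lower number a more polar compound. It stands level with compound 1 `CN(CCCN1CCCCC1)c1ccc(C(=O)N2CCc3ccc(OS(N)(=O)=O)cc3C2)cc1`, which gives 1.93, and with compound 3 `NS(=O)(=O)Oc1ccc2c(c1)CN(C(=O)c1ccc(N3CCCCC3)cc1)CC2`, which gives 1.93; the steps of no change at the digits printed from compound 1 to compound 2 (within the scatter), no change at the digits printed from compound 1 to compound 3 (within the scatter) and no change at the digits printed from compound 2 to compound 3 (within the scatter) all stay within the scatter. Compound 4 `CCN(Cc1ccccn1)c1ccc(C(=O)N2CCc3ccc(OS(N)(=O)=O)cc3C2)cc1` is not yet measured. It differs from compound 2 as follows: pyridin-2-yl in place of 3-bromophenyl on a saturated chain carbon bound to a nitrogen on an aromatic ring. Going by the values given here, none of the measured steps exchanges an aromatic ring of carbon only for one with a hetero atom, so none bears directly on this change; they show only that the series has been flat so far. The counted difference loses a bromine and gains a hydrogen-bond acceptor, so a downward step is expected: a number 0.93 log units lower from compound 2 to compound 4 (beyond the scatter). Compound 4 is estimated at 1, between 0.3 and 1.7.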

Compound 4, partition coefficient: 1.93
Compound 4: the middle estimate sits 0.93 log units below what was measured; measured number outside the range, above it.
By their numbers in this assay, from the lowest: compounds 1, 2, 3 and 4 (each within the scatter of the next).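

In this assay, going by these compounds alone, the exchange of pyridin-2-yl for 3-bromophenyl on a saturated chain carbon bound to a nitrogen on an aromatic ring shows no change at the digits printed from compound 2 to compound 4 (within the scatter) and is the first measured swap of an aromatic ring of carbon only for one with a hetero atom. The flat reading also holds against the other amino groups, with no change at the digits printed from compound 3 to compound 4 (within the scatter) and no change at the digits printed from compound 1 to compound 4 (within the scatter) on the same read-out. No evidence at hand accounts for this result.

Going by these compounds, whether a carboxylic acid in place of the pyridin-2-yl would also leave the number flat stays open. So does the effect of a longer chain in place of the ethyl.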